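The compounds below may be only part of what the source reports. "The series", "measured", "known", "first", "only" and "open" are said of these compounds alone.

Working notes on the series. Compound 1 `Cc1ccc(-c2cc(/N=C3/NC(=O)CS3)cs2)cc1` and compound 2 `COc1ccc(-c2cc(/N=C3/NC(=O)CS3)cs2)cc1` share one core. Compound 3 `COc1ccc(/C=C2\S/C(=N\c3csc(-c4ccc(Cl)cc4)c3)NC2=O)cc1` is built on a different core, and the difference between the two cores is not broken down here. Compound 4 `Cc1ccc(/C=C2\S/C(=N\c3csc(-c4ccc(Cl)cc4)c3)NC2=O)cc1` is the analogue of compound 3 that has yet to be measured.

In a functional assay on HCT-116 cells (Homo sapiens) for cytotoxicity, read by MTT assay, with a stated time of 72 h (a higher number here means a weaker inhibitor, a lower number a stronger inhibitor), compound 1 gives > 50000 nM, which is a limit of the assay and not a number. In this assay compound 2 gives > 50000 nM, again a limit. Between these two compounds the structural change is methyl in place of methoxy on an aromatic carbon, and the step it made, a step that the two limits leave unreadable from compound 2 to compound 1, cannot be read because the limit of > 50000 nM in this assay, at which 2 of the 3 values shown sit, covers both ends. In this assay, for the measured compounds named here, compound 3 gives 1300 nM, the only number obtained so far.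

Compound 4 differs from compound 3 by methyl in place of methoxy on an aromatic carbon, the same change that separates compound 2 from compound 1. That earlier pair says nothing about how large this step can be, as both of its values sit at the limit. Going by the values given here, the only anchor is compound 3 with its value of 1300 nM, and the change itself is modest, exchanging methoxy for methyl. In this assay the step is expected to stay small, around a 1.4-fold higher number from compound 3 to compound 4 (0.14 log units; within the scatter). For compound 4 the value expected in this assay is 1800 nM, with a likely span from 600 nM to 6000 nM.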

Compound 4, half-maximal inhibitory concentration: 1000 nM
The estimate for compound 4 lay 1.8-fold (0.26 log units) above the measured number, and the stated range covers the measured number.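

Working notes on the exchange across cores. On the core of compound 3, methyl in place of methoxy on an aromatic carbon makes a 1.3-fold lower number from compound 3 to compound 4 (0.11 log units; within the scatter) in this assay, so on this core the 4-methoxyphenyl and 4-methylphenyl forms cannot be told apart. Compound 1 and compound 2 each sit at a limit of the assay and not a number, so the step between them cannot be read and the comparison across the two cores has only one readable side: the limit of > 50000 nM in this assay, at which 2 of the 4 values shown sit. The series therefore holds a single readable pair for this change, which shows how the exchange reads on one core but neither supports nor contradicts the idea that it reads the same way on the other.

Going by these compounds, whether a group of another kind on the same aromatic carbon, para to a large group, such as an amine or a carboxylic acid, would give a step beyond the scatter remains open. Also open is which part of the difference between the two cores goes with the readable numbers of compound 3 and compound 4, since that difference is not broken down in the compounds shown.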